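Moving one methyl group on the oxazole ring

The source may report more compounds than this note shows. Statements on the series, on what has been measured and on what is new or still open speak of the compounds shown alone.

In an ADME assay on microsomes (Homo sapiens) for metabolic stability (a higher number here means that the compound lasts longer, a lower number that the compound disappears faster), compound 1 (`Cc1coc(Cn2nc3ccc(-c4ccc(OC(F)(F)F)cc4)cn3c2=O)n1`) gives 2.4 h and compound 2 (`O=c1n(Cc2noc(CO)n2)nc2ccc(-c3ccc(Oc4ccc(F)cc4)cc3)cn12`) gives 1.35 h with the two within the usual scatter of each other. Compound 3 (`Cc1cnc(Cn2nc3ccc(-c4ccc(OC(F)(F)F)cc4)cn3c2=O)o1`) has the same atoms as compound 1, joined differently: 5-methyl-1,3-oxazol-2-yl in place of 4-methyl-1,3-oxazol-2-yl on a saturated chain carbon bound to an aromatic nitrogen. Among the compounds with values here, no measured pair shows such a change, so in this assay the expected step (a 1.1-fold lower number from compound 1 to compound 3 (0.06 log units; within the scatter)) stays within the usual scatter, in neither direction. The half-life estimated for compound 3 is 2.1 h (expected range 1 h to 4.2 h).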

Compound 3, half-life: 4.8 h
Beside the measured number, compound 3's estimate is 2.3-fold (0.36 log units) below it; measured number above the stated range.
By their numbers in this assay, from the lowest: compounds 2, 1 and 3 (each within the scatter of the next, the first and the last beyond it).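

Within the data shown here, compound 3 supplies the first pair that differs in one place, and in this assay moving the methyl from 4-methyl-1,3-oxazol-2-yl to 5-methyl-1,3-oxazol-2-yl gives a 2.0-fold higher number from compound 1 to compound 3 (0.30 log units; within the scatter). On a saturated chain carbon bound to an aromatic nitrogen, this swap of two groups with the same atoms therefore cannot be told apart from repeat variation. No data at hand speak to why the number reads as it does.

The compounds shown leave open how an ethyl group or an amine on the oxazole ring would fare, and whether the same methyl move behaves alike on another core.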